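Methyl to trifluoromethyl at two ring positions

A few compounds are considered here, and "the series" means these few. Any claim that something is new, unique, unknown or untested is made for them only; others in the source may bear on it.

Measured so far:
compound 1 `O=C1NC(=O)C(Cc2ccc(Oc3ccc(C(F)(F)F)cn3)cc2)S1`: 558 nM
compound 2 `Cc1ccnc(Oc2ccc(CC3SC(=O)NC3=O)cc2)c1`: 4280 nM
compound 3 `Cc1ccc(Oc2ccc(CC3SC(=O)NC3=O)cc2)nc1`: 4470 nM

All three were read in a functional assay for agonist activity at Free fatty acid receptor 1 (Homo sapiens), read by FLIPR, in the presence of a further agent that is not named here; a higher number here means that more compound is needed for the effect, a lower number that less compound is needed. Compound 2 and compound 3 have the same atoms joined differently; the difference is 4-methylpyridin-2-yl in place of 5-methylpyridin-2-yl on an oxygen on an aromatic ring, and the step of a 1.0-fold higher number from compound 2 to compound 3 (0.02 log units; within the scatter) lies within the scatter, so neither stands above the other. Compound 1 differs from compound 3 by trifluoromethyl in place of methyl on an aromatic carbon, giving an 8.0-fold lower number from compound 3 to compound 1 (0.90 log units; beyond the scatter). Compound 4 `O=C1NC(=O)C(Cc2ccc(Oc3cc(C(F)(F)F)ccn3)cc2)S1` is not yet measured; it differs from compound 2 by trifluoromethyl in place of methyl on an aromatic carbon. This is the same kind of change as that from compound 3 to compound 1, not the same one: there the place was two atoms from the ring nitrogen and para to a large group, here it is meta to a large group and opposite the ring nitrogen. Among the measured compounds shown here, only one measured instance of the change exists, at the other place, so the size is uncertain. The expected step is a 4.8-fold lower number from compound 2 to compound 4 (0.68 log units; beyond the scatter), resting on an 8.0-fold lower number from compound 3 to compound 1 (0.90 log units; beyond the scatter). Compound 4 is expected at 900 nM, with a likely range from 300 nM to 2700 nM.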

Compound 4, half-maximal effective concentration: 237 nM
Beside the measured number, compound 4's estimate is 3.8-fold (0.58 log units) above it; the measured number lies below the stated range.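

In this assay, trifluoromethyl in place of methyl at the second ring place gives an 18-fold lower number from compound 2 to compound 4 (1.26 log units; beyond the scatter). Set beside the earlier step, the two instances do not separate, so the change carries across this pair of cores as a lowering of similar size: the same change on two cores in this assay, an 8.0-fold lower number (0.90 log units; beyond the scatter) from compound 3 to compound 1 and an 18-fold lower number (1.26 log units; beyond the scatter) from compound 2 to compound 4, 2.3-fold (0.35 log units) apart, within the scatter of two such steps. Among the compounds shown here, this rests on only two matched pairs, both with the same ring with 1 nitrogen and the same remaining structure, so it does not show that the step would hold on a more distant core, nor does it give any reason for the step.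

Still open, from the compounds shown here alone, is how a nitrile, an amine or a longer chain at either place would read in this assay. Also open, going by these compounds, is whether the step survives on a core ending in a carboxylic acid.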